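Swapping a hydroxyphenyl for a dichlorophenyl on the shared core

The source may report more compounds than this note shows. Statements on the series, on what has been measured and on what is new or still open speak of the compounds shown alone.

Compound 1 `O=C(CN1C(=O)c2ccccc2C1=O)NN1C(=O)CSC1c1ccccc1O` is the lower of the two compounds measured in a physicochemical assay for lipophilicity, in phosphate buffer, measured as octanol-water partition, with a stated time of 24 h (on this read-out higher numbers stand for higher lipophilicity and lower numbers for lower lipophilicity), where compound 1 gives 1.46. Going by the values given here, its only measured neighbour is compound 2 `O=C(CN1C(=O)c2ccccc2C1=O)NN1C(=O)CSC1c1ccc(O)cc1`, which in this assay gives 2.4; the step of a number 0.94 log units higher from compound 1 to compound 2 (beyond the scatter) shows that moving the hydroxyl from one position of the ring to another already shifts the reading noticeably. Compound 3 `O=C(CN1C(=O)c2ccccc2C1=O)NN1C(=O)CSC1c1ccc(Cl)cc1Cl` has not been measured yet. It differs from compound 1 as follows: 2,4-dichlorophenyl in place of 2-hydroxyphenyl on a saturated ring carbon. Among the compounds with values here, no measured step covers the loss of a hydroxyl together with the gain of two chlorines, so the only guide is that a change on this ring moved the reading by a number 0.94 log units higher from compound 1 to compound 2 (beyond the scatter), and the present change removes the one donor and acceptor while adding two chlorines, which is expected to push the number further in the same direction. The estimate for compound 3 is therefore 3.8, within 3 to 4.6, an expected step of a number 2.34 log units higher from compound 1 to compound 3 (beyond the scatter).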

Compound 3, partition coefficient: 2.54
Compound 3: middle estimate off by 1.26 log units, on the high side; the measured number lies below the stated range.
By their numbers in this assay, from the lowest: compound 1; then compounds 2 and 3 (each within the scatter of the next).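

In this assay, putting 2,4-dichlorophenyl in place of 2-hydroxyphenyl on the saturated ring carbon gives a step of a number 1.08 log units higher from compound 1 to compound 3 (beyond the scatter), so this position can carry a change of this size on the read-out. The same group in place of 4-hydroxyphenyl gives only a number 0.14 log units higher from compound 2 to compound 3 (within the scatter), which means compound 2 and compound 3 cannot be told apart here, and compound 1 alone sits apart from the other two. Nothing measured here explains why these two quite different groups give readings that cannot be separated.

Still open, as far as these compounds go, is how a single chlorine, as in 4-chlorophenyl, would compare with compound 3 on this carbon. Also open, from the compounds shown here alone, is how an amine or a carboxylic acid on this phenyl ring would read.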